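The source may hold more compounds than are shown below. What is called first, only, known or untested is meant among the compounds shown, and "the series" means these compounds.

Measured so far in a functional assay on PC-3 cells (Homo sapiens) for antiproliferative activity, read by MTT assay; on this read-out lower numbers stand for stronger inhibition and higher numbers for weaker inhibition:
compound 1 `Cn1c(=O)c(=O)n(C2CCCC2)c2nc(N/N=C/c3ccccc3F)ncc21` gives 27600 nM
compound 2 `Cn1c(=O)c(=O)n(C2CCCC2)c2nc(N/N=C/c3ccc(O)c(Br)c3)ncc21` gives 11600 nM

Compound 2 stands lowest of the two numbers in this assay; the step of a 2.4-fold lower number from compound 1 to compound 2 (0.38 log units; beyond the scatter) is modest. Compound 3 `CSc1ccc(/C=N/Nc2ncc3c(n2)n(C2CCCC2)c(=O)c(=O)n3C)cc1` carries the change (4-(methylsulfanyl)phenyl in place of 3-bromo-4-hydroxyphenyl on a carbon with a double bond to nitrogen). Going by the values given here, only one measured step bears on it, the aryl swap from compound 1 to compound 2, so the direction is uncertain; the hydrogen-bond donor of compound 2 leaves. A small step is expected, most likely back toward the number of compound 1, a 1.4-fold higher number from compound 2 to compound 3 (0.14 log units; within the scatter). Compound 3 is estimated at 16000 nM, with a range of 5000 nM to 45000 nM.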

Compound 3, half-maximal inhibitory concentration: 21000 nM
The estimate for compound 3 lay 1.3-fold (0.12 log units) below the measured number; measured number inside the range.
By their numbers in this assay, from the lowest: compounds 2, 3 and 1 (each within the scatter of the next, the first and the last beyond it).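

In this assay the swap to 4-(methylsulfanyl)phenyl gives a 1.8-fold higher number from compound 2 to compound 3 (0.26 log units; within the scatter) and a 1.3-fold lower number from compound 1 to compound 3 (0.12 log units; within the scatter) and so cannot be separated from either earlier aryl group. At this carbon with a double bond to nitrogen, losing the hydrogen-bond donor of 3-bromo-4-hydroxyphenyl thus gives no step beyond the scatter, and only compound 1 and compound 2 stand beyond it from each other. Nothing available here speaks to why the numbers fall as they do.

Still open, from the compounds shown here alone, is whether an aryl group carrying an amine or a carboxylic acid, or a cyclohexyl group in place of the aryl ring, would move the number well outside this range.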